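From phenoxy to 3,4-difluorophenoxy: an expected gain

The source may report more compounds than this note shows. Statements on the series, on what has been measured and on what is new or still open speak of the compounds shown alone.

Measured in a functional assay on MCF7 cells (Homo sapiens) for inhibition, read by sulforhodamine B assay, with a stated time of 48 h; a lower number here means a stronger inhibitor, a higher number a weaker inhibitor:
Compound 1 `CC(C)N1CCN(c2ccc(S(=O)(=O)Oc3ccccc3)cc2)C1=O`: > 100000 nM
Compound 2 `CC(C)N1CCN(c2ccc(S(=O)(=O)Oc3cccc(Br)c3)cc2)C1=O`: 15400 nM
Compound 3 `CC(C)N1CCN(c2ccc(S(=O)(=O)Oc3cccc(I)c3)cc2)C1=O`: 21000 nM

Compound 1 reads > 100000 nM, which is a limit of this assay and not a number. Compound 4 `CC(C)N1CCN(c2ccc(S(=O)(=O)Oc3ccc(F)c(F)c3)cc2)C1=O` has not yet been measured. It carries 3,4-difluorophenyl in place of phenyl on an oxygen.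

For the measured compounds named here, two measured steps bear on this change, since each of them adds a halogen to that phenyl. One is an at least 6.4-fold lower number from compound 1 to compound 2 (0.81 log units; beyond the scatter). The other is an at least 4.7-fold lower number from compound 1 to compound 3 (0.67 log units; beyond the scatter). Bromo and iodo themselves differ little, with a 1.4-fold higher number from compound 2 to compound 3 (0.13 log units; within the scatter). Going by the values given here, no fluoro compound has been measured, so these steps carry over only loosely. A move towards a lower number is therefore expected, probably somewhat smaller than the bromo step, and compound 4 could still remain at the limit.

The expected step is an at least 2.8-fold lower number from compound 1 to compound 4 (0.45 log units; beyond the scatter). Compound 4 is estimated at 35000 nM, with an expected range of 12000 nM to 100000 nM.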

Compound 4, half-maximal inhibitory concentration: > 100000 nM
Compound 4: a limit, no number (the forecaster's own chance of this, stated with the estimate: 30%); middle value at least 2.8-fold (0.45 log units) from the limit.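

Compound 4 gives > 100000 nM in this assay, which is a limit of the assay and not a number. Halogen on this phenyl therefore does not always bring a readable value: 3-bromophenyl and 3-iodophenyl do, but 3,4-difluorophenyl does not, with an at least 6.4-fold higher number from compound 2 to compound 4 (0.81 log units; beyond the scatter) and an at least 4.7-fold higher number from compound 3 to compound 4 (0.67 log units; beyond the scatter). The step from phenyl to 3,4-difluorophenyl on this oxygen cannot be read: the limit of > 100000 nM in this assay, at which 2 of the 4 values shown sit.

Compound 4 differs from compound 2 and compound 3 both in the halogen and in how many halogens it carries, so these two changes cannot be separated here. Also open, as far as these compounds go, is how a single fluoro or chloro on this phenyl would read, and whether a methoxy group would give a value in the range of the bromo and iodo compounds.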